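Ester variation at the shared core: antiproliferative working notes

The compounds below may be only part of what the source reports. "The series", "measured", "known", "first", "only" and "open" are said of these compounds alone.

Measured compounds:
compound 1, `CC1=CCC2C(CC[C@@]2(C)O)C(C)(C)C1CC[C@@H]1[C@@]2(C)CCC(=O)C(C)(C)O[C@@H]2CC[C@]1(C)O`, gives in a functional assay on MDA-MB-231 cells (Homo sapiens) for antiproliferative activity, read by MTT assay, with a stated time of 72 h (on this read-out higher numbers stand for weaker inhibition and lower numbers for stronger inhibition), a limit of > 50000 nM.
compound 2, `CC(=O)O[C@H]1CC[C@]2(C)[C@H](CC[C@@](C)(O)[C@H]2CC[C@@H]2C(C)=CC[C@H]3[C@H](CC[C@]3(C)OC(C)=O)C2(C)C)OC1(C)C`, gives 26200 nM.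
compound 3, `CC1=CC[C@H]2[C@H](CC[C@]2(C)O)C(C)(C)[C@@H]1CC[C@H]1[C@]2(C)CC[C@H](OC(=O)c3ccncc3)C(C)(C)O[C@H]2CC[C@@]1(C)O`, gives 18000 nM.

Compound 3 holds the lowest of the two numbers, with compound 2 its nearest neighbour and within the scatter of it; the value of compound 1 is a limit of the assay only (the limit of > 50000 nM in this assay, at which 1 of the 3 values shown sits). For the measured compounds named here, no single-point step between measured compounds is available.

Compound 4, `CC1=CC[C@H]2[C@H](CC[C@]2(C)O)C(C)(C)[C@@H]1CC[C@H]1[C@]2(C)CC[C@H](OC(=O)c3ccc([N+](=O)[O-])o3)C(C)(C)O[C@H]2CC[C@@]1(C)O`, differs from compound 3 by 5-nitrofuran-2-yl in place of pyridin-4-yl on a carbonyl carbon. The change is expected to move the number only a little, downward if at all, within or near the scatter: the step of a 1.4-fold lower number from compound 3 to compound 4 (0.14 log units; within the scatter) is the working estimate. Compound 4 is therefore expected near 13000 nM, between 4500 nM and 38000 nM.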

Compound 4, half-maximal inhibitory concentration: 11100 nM
Compound 4: middle estimate off by 1.2-fold (0.07 log units), on the high side; the measured number falls inside the stated range.
By their numbers in this assay, from the lowest: compounds 4, 3 and 2 (each within the scatter of the next, the first and the last beyond it). At a limit, above all of these: compound 1.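

On a carbonyl carbon, 5-nitrofuran-2-yl in place of pyridin-4-yl gives a 1.6-fold lower number from compound 3 to compound 4 (0.21 log units; within the scatter) in this assay, the only single-place comparison shown at this position. Two quite different aromatic rings on this carbonyl carbon are therefore not told apart by this read-out, so the position tolerates this exchange without a change beyond the scatter. Nothing shown bears on the cause of this result. Still open, as far as these compounds go, is how an amine, a carboxylic acid or a longer alkyl chain on this carbonyl carbon would read.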